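The source may report more compounds than this note shows. Statements on the series, on what has been measured and on what is new or still open speak of the compounds shown alone.

Of the compounds shown here, two have numbers so far in a functional assay on HL-60 cells (Homo sapiens) for cytotoxicity, read by WST assay, with a stated time of 48 h (a higher number here means that more compound is needed for the effect, a lower number that less compound is needed), on this series. Compound 1 (`O=C1OC[C@H](Cc2ccccc2)[C@H]1Cc1cccc(OC(F)(F)F)c1`) gives 34000 nM here. Compound 2 (`COc1ccccc1C[C@H]1COC(=O)[C@@H]1Cc1ccc(Cl)c(Cl)c1`) gives 14000 nM and stands lowest of the two numbers, with its gap to compound 1 beyond the scatter. Compound 3 (`CCCCOc1ccccc1C[C@H]1COC(=O)[C@@H]1Cc1ccc(Cl)c(Cl)c1`) differs from compound 2 in one place (propyl in place of hydrogen on a saturated chain carbon bound to an oxygen on an aromatic ring) with propyl in place of hydrogen on a saturated chain carbon bound to an oxygen on an aromatic ring, so that methoxy becomes butoxy. For the measured compounds named here, compound 1 and compound 2 differ in more than one place, and no measured pair isolates this change, so the expectation is loose. No change beyond the scatter is expected, with at most a slight drift toward a lower number in the estimated step (a 1.4-fold lower number from compound 2 to compound 3 (0.15 log units; within the scatter)) for now. The estimate for compound 3 is 10000 nM with an expected range (3500 nM to 30000 nM) still wide.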

Compound 3, half-maximal effective concentration: 10000 nM
Compound 3: middle estimate and measured number agree at the digits printed, within the range that was stated.
By their numbers in this assay, from the lowest: compounds 3 and 2 (each within the scatter of the next); then compound 1.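

In this assay, propyl in place of hydrogen on a saturated chain carbon bound to an oxygen on an aromatic ring, which turns methoxy into butoxy, gives a 1.4-fold lower number from compound 2 to compound 3 (0.15 log units; within the scatter). For the compounds shown here, this is the first step that isolates a single place, and it shows that this position carries the longer butoxy chain with no change that can be told from the scatter. Nothing measured here speaks to the origin of this result.

Going by these compounds, whether a longer chain such as hexyloxy, or a chain carrying an amine or a carboxylic acid, moves the number beyond the scatter stays open. On these data alone, compound 1 differs from compound 2 in more than one place, so whether the same change behaves alike on the core of compound 1 also stays open.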